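Shifting a Hydroxyl Group Across Two Compound Pairs

The source may hold more compounds than are shown below. What is called first, only, known or untested is meant among the compounds shown, and "the series" means these compounds.

Compound 1 `Oc1cccc(-c2cc(-c3cccs3)cc(-c3ccccc3O)n2)c1`: > 50000 nM in a functional assay on T47D cells (Homo sapiens) for cytotoxicity, read by CCK-8 assay (a lower number here means a stronger inhibitor, a higher number a weaker inhibitor), a limit.
Compound 2 `Oc1ccc(-c2cc(-c3cccs3)cc(-c3ccccc3O)n2)cc1`: > 50000 nM in this assay, a limit.
Compound 3 `Oc1cccc(-c2cc(-c3ccco3)cc(-c3cccc(O)c3)n2)c1`: 3520 nM in this assay.

Compound 1 and compound 2 differ by 4-hydroxyphenyl in place of 3-hydroxyphenyl on an aromatic carbon. The step that the two limits leave unreadable from compound 1 to compound 2 cannot be read, because of the limit of > 50000 nM in this assay, at which 2 of the 3 values shown sit. Compound 3 carries a different core; the difference between the two cores is not broken down here. Compound 4 `Oc1ccc(-c2cc(-c3ccco3)cc(-c3cccc(O)c3)n2)cc1`, not yet measured, is related to compound 3 by 4-hydroxyphenyl in place of 3-hydroxyphenyl on an aromatic carbon. This is the same kind of change as that from compound 1 to compound 2, not the same, since the place differs: there the changed group sat meta to a 2-hydroxyphenyl group and meta to a thiophen-2-yl group, here it sits meta to a 3-hydroxyphenyl group and meta to a furan-2-yl group. The earlier pair offers no readable size, so the expectation for compound 4 rests on compound 3 alone with its value 3520 nM in this assay. Compound 4 is expected to show a step of a 1.4-fold higher number from compound 3 to compound 4 (0.15 log units; within the scatter) from compound 3, within ordinary scatter. Compound 4 is estimated at 5000 nM, between 1500 nM and 20000 nM.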

Compound 4, half-maximal inhibitory concentration: 1280 nM
For compound 4 the middle estimate is 3.9-fold (0.59 log units) above the measured one; measured number below the stated range.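

In this assay, 4-hydroxyphenyl in place of 3-hydroxyphenyl gives a 2.8-fold lower number from compound 3 to compound 4 (0.44 log units; beyond the scatter), a modest step that lies beyond the scatter. The same kind of change on the core of compound 1 cannot be read, so the series offers only one readable size for it and no second size to compare it with: the limit of > 50000 nM in this assay, at which 2 of the 4 values shown sit. Whether the step carries from one core to another is therefore not shown, and the result applies only where the changed group sits meta to a 3-hydroxyphenyl group and meta to a furan-2-yl group.

As far as these compounds go, compound 1 and compound 3 differ in more than one place, so it remains open what the thiophen-2-yl group or the furan-2-yl group alone contributes on an otherwise matched core. From the compounds shown here alone, it also remains open how an amine or a carboxylic acid in place of the hydroxyl of the 4-hydroxyphenyl group would read in this assay.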